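The source may hold more compounds than are shown below. What is called first, only, known or untested is meant among the compounds shown, and "the series" means these compounds.

In a functional assay on HL-60 cells (Homo sapiens) for cytotoxicity, read by MTT assay, with a stated time of 72 h (a lower number here means a stronger inhibitor, a higher number a weaker inhibitor), compound 1 (`Cc1ccc(S(=O)(=O)c2nc3ccccc3nc2N2CCCC2)cc1`) gives 9720 nM while compound 2 (`COc1ccc(S(=O)(=O)c2nc3ccccc3nc2N2CCCC2)cc1`) gives 16000 nM and compound 3 (`O=S(=O)(c1ccc(F)cc1)c1nc2ccccc2nc1N1CCCC1`) gives 12800 nM in the same range. The steps between them (a 1.6-fold higher number from compound 1 to compound 2 (0.22 log units; within the scatter) and a 1.3-fold higher number from compound 1 to compound 3 (0.12 log units; within the scatter)) are small, so compound 1 stands level with both. Compound 4 (`Cc1ccc(S(=O)(=O)c2nc3ccccc3nc2N2CCC(O)CC2)cc1`) has 4-hydroxypiperidin-1-yl in place of pyrrolidin-1-yl on an aromatic carbon next to the ring nitrogen. Neither a 1.6-fold higher number from compound 1 to compound 2 (0.22 log units; within the scatter) nor a 1.3-fold higher number from compound 1 to compound 3 (0.12 log units; within the scatter) touches this group, so these steps offer no direction, and no change beyond the scatter is expected in this assay for now. The expected step is small (a 1.2-fold higher number from compound 1 to compound 4 (0.09 log units; within the scatter)) but uncertain. Compound 4 is estimated at 12000 nM (expected range 4000 nM to 35000 nM).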

Compound 4, half-maximal inhibitory concentration: 4050 nM
The estimate for compound 4 lay 3.0-fold (0.47 log units) above the measured number, and the stated range covers the measured number.
By their numbers in this assay, from the lowest: compound 4; then compounds 1, 3 and 2 (each within the scatter of the next).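

For the compounds shown here, the earlier steps all left pyrrolidin-1-yl in place and stayed within the scatter, whereas replacing it with 4-hydroxypiperidin-1-yl in this assay gives a 2.4-fold lower number from compound 1 to compound 4 (0.38 log units; beyond the scatter), the first step beyond the scatter. This position therefore responds to change, at least modestly. The swap enlarges the ring and adds a hydroxyl together, and no available measurement explains the step.

On these data alone, whether plain piperidin-1-yl or morpholin-4-yl would give a similar number remains open. So does whether the same swap would carry over to the methoxy and fluoro analogues, compound 2 and compound 3.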